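A few compounds are considered here, and "the series" means these few. Any claim that something is new, unique, unknown or untested is made for them only; others in the source may bear on it.

Compound 1 `O=C(NCCNS(=O)(=O)c1ccc(-c2ccccc2OCc2cccc(O)c2)s1)Nc1cc(C(F)(F)F)cc(C(F)(F)F)c1` gives 3000 nM 
Compound 2 `O=[N+]([O-])c1ccc(NC(=S)NCCNS(=O)(=O)c2ccc(-c3ccccc3OCc3cccc(O)c3)s2)cc1` gives 10100 nM 
Compound 3 `O=S(=O)(NCCNC(=S)Nc1cc(C(F)(F)F)cc(C(F)(F)F)c1)c1ccc(-c2ccccc2Oc2ccc(O)c(O)c2)s1` gives 10300 nM 

In a functional assay on RS4-11 cells (Homo sapiens) for inhibition, read by CCK-8 assay, with a stated time of 48 h (on this read-out higher numbers stand for weaker inhibition and lower numbers for stronger inhibition), compound 1 holds the lowest of these three numbers, and compound 2 and compound 3 each lie beyond the scatter from it. Compound 4 `O=C(NCCNS(=O)(=O)c1ccc(-c2ccccc2Oc2ccc(O)c(O)c2)s1)Nc1cc(C(F)(F)F)cc(C(F)(F)F)c1` is still unmeasured. It departs from compound 1 by 3,4-dihydroxyphenyl in place of 3-hydroxybenzyl on an oxygen on an aromatic ring with 3,4-dihydroxyphenyl in place of 3-hydroxybenzyl on an oxygen on an aromatic ring. Among the compounds with values here, no measured pair shows this change alone. A moderate step to a higher number, meaning weaker inhibition, is expected in this assay because compound 3 with 3,4-dihydroxyphenyl gives 10300 nM in that read-out. The expected step is a 1.8-fold higher number from compound 1 to compound 4 (0.26 log units; within the scatter) as estimated here. For compound 4 the estimate is 5500 nM with an expected range of 2300 nM to 13000 nM.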

Compound 4, half-maximal inhibitory concentration: 4900 nM
For compound 4 the middle estimate is 1.1-fold (0.05 log units) above the measured one; low and high end bracket the measured number.
By their numbers in this assay, from the lowest: compounds 1 and 4 (each within the scatter of the next); then compounds 2 and 3 (each within the scatter of the next).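

In this assay, the exchange of 3-hydroxybenzyl for 3,4-dihydroxyphenyl on an oxygen on an aromatic ring gives a 1.6-fold higher number from compound 1 to compound 4 (0.21 log units; within the scatter). Within the data shown here, this is the first pair to show that change alone, and on the core of compound 1 the two groups cannot be told apart in this read-out. No measurement offered here explains this result.

The compounds shown leave open how a ring carrying an amine or a carboxylic acid would fare in this position. A single pair also cannot show whether the result holds on other cores.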